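This account rests on a few compounds, and the source may have more. Where it says the series, first, only, none or still open, it means among the compounds named here.

Measured so far:
compound 1, `Cn1nc2c(=O)n(CC3(O)CCN(Cc4ccc(-c5ccco5)cc4Cl)CC3)cnc2c1-c1ccc(CNCCO)cc1`: 8.2 nM
compound 2, `Cn1cc(-c2ccc(CN3CCC(O)(Cn4cnc5c(-c6ccc(CN)cc6)n(C)nc5c4=O)CC3)c(Cl)c2)cn1`: 291 nM

In an assay on isolated protein for inhibition of ubiquitin carboxyl-terminal hydrolase 7 (Homo sapiens), with stated times of 30 min and 2 h (on this read-out lower numbers stand for stronger inhibition and higher numbers for weaker inhibition), compound 1 holds the lower of the two numbers recorded; compound 2 gives 291 nM, a gap from compound 1 well beyond the scatter. Compound 3, `Cn1nc2c(=O)n(CC3(O)CCN(Cc4ccc(-c5ccco5)cc4Cl)CC3)cnc2c1-c1ccc(CNS(C)(=O)=O)cc1`, is not yet measured. It differs from compound 1 by methylsulfonyl in place of 2-hydroxyethyl on an amine nitrogen. Among the measured compounds shown here, no measured pair shows this exchange, so nothing recorded fixes its size. The expectation is a modest shift towards weaker inhibition, a 2.4-fold higher number from compound 1 to compound 3 (0.39 log units; beyond the scatter). Compound 3 is estimated at 20 nM, with a range from 5 nM to 80 nM.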

Compound 3, half-maximal inhibitory concentration: 65.3 nM
Beside the measured number, compound 3's estimate is 3.3-fold (0.51 log units) below it; measured number inside the range.
By their numbers in this assay, from the lowest: compound 1; then compound 3; then compound 2.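

In this assay, among the compounds shown here, the amine nitrogen proves sensitive to its substituent: methylsulfonyl in place of 2-hydroxyethyl gives an 8.0-fold higher number from compound 1 to compound 3 (0.90 log units; beyond the scatter), a modest step but the first reading of any exchange at this position. The position therefore does not treat these two groups alike, although the methanesulfonamido compound keeps measurable inhibition. Nothing available explains the step. Still open, from the compounds shown here alone, is whether the loss follows the sulfonyl group or the absence of the hydroxyl. An acetyl group or a 3-hydroxypropyl chain on the same nitrogen would help separate these readings.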